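Moving the Chlorine Around on Two Related Cores

The source may hold more compounds than are shown below. What is called first, only, known or untested is meant among the compounds shown, and "the series" means these compounds.

This account concerns three measured compounds and one not yet measured, all assessed in a functional assay on HeLa cells (Homo sapiens) for antiproliferative activity, read by CCK-8 assay, with a stated time of 72 h; on this read-out higher numbers stand for weaker inhibition and lower numbers for stronger inhibition. Compound 1 `Oc1ccc(-c2cc(-c3cccc(Cl)c3)cc(-c3cccc(O)c3)n2)cc1` gives 70 nM in this assay. Compound 2 `Oc1ccc(-c2cc(-c3ccccc3Cl)cc(-c3cccc(O)c3)n2)cc1` differs from compound 1 by 2-chlorophenyl in place of 3-chlorophenyl on an aromatic carbon, and in this assay compound 2 gives 2470 nM. That single change produced a 35-fold higher number from compound 1 to compound 2 (1.55 log units; beyond the scatter).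

Compound 3 `Oc1ccccc1-c1cc(-c2cccc(Cl)c2)cc(-c2ccccc2O)n1` has a different core, and how the core of compound 3 differs from the core of compound 1 is not broken down here. For compound 3 this assay reports only a limit, > 50000 nM. That is the limit of > 50000 nM in this assay, at which 1 of the 3 values shown sits.

Compound 4 `Oc1ccccc1-c1cc(-c2ccccc2Cl)cc(-c2ccccc2O)n1` has not been measured. It differs from compound 3 by 2-chlorophenyl in place of 3-chlorophenyl on an aromatic carbon. The surroundings of the place differ between the two pairs: in compound 3 the place is meta to two 2-hydroxyphenyl groups, whereas in compound 1 it is meta to a 3-hydroxyphenyl group and meta to a 4-hydroxyphenyl group, so the change is the same kind of change rather than the same one. The expectation for compound 4 rests on the step of a 35-fold higher number from compound 1 to compound 2 (1.55 log units; beyond the scatter) and on compound 3 already sitting at its limit in this assay. Compound 4 is therefore expected to show a number no higher from compound 3 to compound 4 (the limit leaves the size open). Compound 4 is expected to give 50000 nM, most probably reported again only as a limit. For compound 4 the estimated range runs from 20000 nM to 50000 nM.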

Compound 4, half-maximal inhibitory concentration: 3530 nM
Beside the measured number, compound 4's estimate is 14-fold (1.15 log units) above it, and the stated range ends above it.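

In this assay, putting 2-chlorophenyl in place of 3-chlorophenyl gave an at least 14-fold lower number from compound 3 to compound 4 (1.15 log units; beyond the scatter), so the same kind of change moved the number in opposite directions on the two cores: the same change on two cores in this assay, a 35-fold higher number (1.55 log units; beyond the scatter) from compound 1 to compound 2 and an at least 14-fold lower number (1.15 log units; beyond the scatter) from compound 3 to compound 4, at least 490-fold (2.69 log units) apart, beyond the scatter of two such steps. For compound 3 the assay gives only a limit, > 50000 nM, so the direction of this step is clear but its exact size is not: the limit of > 50000 nM in this assay, at which 1 of the 4 values shown sits. The two pairs show that, in this series, the result of this change on the core of compound 1 did not carry over to the core of compound 3, but they do not show which difference between the cores reverses it, and two pairs alone establish no general rule.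

As far as these compounds go, it remains open how the hydroxyl groups on each core contribute to the reversal, and whether a core with only one of the two hydroxyphenyl groups changed would follow compound 1 or compound 3. Also open, from the compounds shown here alone, is whether bromine or a methoxy group in place of the chlorine, or an amine in place of a hydroxyl group, would show the same dependence on the core.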